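Dimethylamino for propyl on the carbonyl of compound 2

A few compounds are considered here, and "the series" means these few. Any claim that something is new, unique, unknown or untested is made for them only; others in the source may bear on it.

Measured in a toxicity assay on NIH3T3 cells (Mus musculus) for cytotoxicity, read by resazurin assay (a lower number here means that less compound is needed, a higher number that more compound is needed for the effect), limits of the assay and not numbers:
Compound 1 `O=C(OC1CCCCC1)c1ccc(NCc2cncn2Cc2ccc(-c3ccccc3)cc2)cc1-c1ccccc1` gives > 10000 nM as a limit
Compound 2 `CCCC(=O)c1ccc(NCc2cncn2Cc2ccc(-c3ccccc3)cc2)cc1-c1ccccc1` gives > 10000 nM as a limit

Compound 2 has no exact position in this assay and gives only > 10000 nM as a limit. The next step leads to compound 3 `CN(C)C(=O)c1ccc(NCc2cncn2Cc2ccc(-c3ccccc3)cc2)cc1-c1ccccc1` and reads dimethylamino in place of propyl on a carbonyl carbon in words dimethylamino in place of propyl on a carbonyl carbon, or propylcarbonyl to dimethylcarbamoyl. Among the compounds with values here, the one measured step at this carbonyl carbon is a step that the two limits leave unreadable from compound 1 to compound 2 and it gives no size to carry over. The series offers only the limit of > 10000 nM in this assay, at which 2 of the 2 values shown sit, as its evidence. No step beyond the scatter is therefore expected in this assay, though this expectation is weakly founded. Compound 3 is expected to be reported as a limit too because the limit of > 10000 nM in this assay, at which 2 of the 2 values shown sit, is all that the series shows so far. The estimated step is a number no higher from compound 2 to compound 3 (the limit leaves the size open) and it carries the same uncertainty. Compound 3 is estimated at 10000 nM with an expected range from 4000 nM to 25000 nM if a number is reported at all.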

Compound 3, half-maximal effective concentration: > 1000 nM
Compound 3 ended at the assay's limit (the forecaster's own chance of this, stated with the estimate: 75%); the middle value does not contradict the limit.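

In this assay compound 3 gives > 1000 nM, a limit of the assay and not a number. Within the data shown here, all three values are limits, and no step among compound 1, compound 2 and compound 3 can be read. The compounds shown leave open where any of the three stands as a number in this assay, and whether a change on the carbonyl carbon shifts that number.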